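The source may report more compounds than this note shows. Statements on the series, on what has been measured and on what is new or still open speak of the compounds shown alone.

Measured compounds:
compound 1, `O=C(NCc1ccc(CNS(=O)(=O)c2ccccc2F)cc1)c1cccnc1`: 100 nM
compound 2, `COc1ccccc1C(=O)NCc1ccc(CNS(=O)(=O)c2ccccc2C)cc1`: 1000 nM

Both numbers come from an assay on MDA-MB-231 cells for displacement of a labelled ligand from C-X-C chemokine receptor type 4 (Homo sapiens), read by fluorescence and microscopy, with stated times of 10 min and 30 min; on this read-out lower numbers stand for an effect already at smaller amounts and higher numbers for an effect only at larger amounts of compound. Compound 2 gives the higher of the two numbers; compound 1 sits at the lower value, and the gap between them lies beyond the usual scatter, so compound 2 is the weaker of the two. The two structures differ in more than one place, so this gap cannot be tied to any single change.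

Compound 3, `Cc1ccccc1S(=O)(=O)NCc1ccc(CNC(=O)c2cccnc2)cc1`, is not yet measured in this assay. It differs from compound 2 in one place: pyridin-3-yl in place of 2-methoxyphenyl on a carbonyl carbon. Going by the values given here, the group that enters is the one compound 1 carries on its carbonyl carbon, while elsewhere compound 3 matches compound 2. Among the compounds with values here, no measured pair isolates this change, so its size can only be read against the spread between compound 1 and compound 2. The expected change for compound 3 is a downward one, a 3.3-fold lower number from compound 2 to compound 3 (0.52 log units; beyond the scatter), beyond the scatter yet not reaching the level of compound 1. For compound 3 the estimate in this assay is 300 nM, within 100 nM to 1000 nM.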

Compound 3, effective concentration (reported as EC, without a stated level of effect): 1000 nM
The estimate for compound 3 lay 3.3-fold (0.52 log units) below the measured number; the measured number falls inside the stated range.
By their numbers in this assay, from the lowest: compound 1; then compounds 2 and 3 (each within the scatter of the next).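

In this assay, going by these compounds alone, the first pair that isolates the carbonyl side shows pyridin-3-yl in place of 2-methoxyphenyl on a carbonyl carbon giving no change at the digits printed from compound 2 to compound 3 (within the scatter), with the methyl on the aromatic carbon held constant. Within this pair, replacing 8 heavy atoms of carbon and oxygen with 6 of carbon and nitrogen therefore leaves the number unmoved, although this is a single comparison and sets no rule for the carbonyl position. The other new pair keeps pyridin-3-yl on the carbonyl carbon and places methyl in place of fluoro on an aromatic carbon, giving a 10-fold higher number from compound 1 to compound 3 (1.00 log units; beyond the scatter), which makes this the only one-place change shown here that lies beyond the scatter.

Going by these compounds, it remains open whether the carbonyl swap would stay as silent with fluoro on the aromatic carbon, and how chloro, methoxy or plain hydrogen on that carbon, or an aminopyridine or a saturated piperidine on the carbonyl carbon, would read. Nothing measured alongside these numbers bears on why the fluoro to methyl step is large while the carbonyl step is not.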